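Bromo in place of 2-methoxyphenyl: notes on compound 4

A few compounds are considered here, and "the series" means these few. Any claim that something is new, unique, unknown or untested is made for them only; others in the source may bear on it.

In a functional assay on HCT-116 cells (Homo sapiens) for antiproliferative activity, read by CellTiter-Glo, with a stated time of 72 h (on this read-out lower numbers stand for stronger inhibition and higher numbers for weaker inhibition), compound 1 (`O=C(NO)c1cccc(/C=C/c2ccnc(-c3ccccc3O)c2)c1`) gives 3360 nM as its result. Compound 2 (`COc1ccccc1-c1cc(/C=C/c2ccc(C(=O)NO)cc2)ccn1`) gives 8440 nM in this assay, the higher of the two numbers in the series, and its gap to compound 1 lies beyond the scatter. Compound 3 (`O=C(NO)c1ccc(/C=C/c2cccc(-c3cccc(O)c3)c2)cc1`) reads > 10000 nM in this assay, and this reading is a limit and not a number.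

The compound still to be measured, compound 4 (`O=C(NO)c1ccc(/C=C/c2ccnc(Br)c2)cc1`), has bromo in place of 2-methoxyphenyl on an aromatic carbon, next to the ring nitrogen (bromo in place of 2-methoxyphenyl on an aromatic carbon). Among the compounds with values here, no two measured compounds differ in one place only, so the series offers no direct size for this change. The estimate therefore stays close to compound 2 at 8440 nM and expects no step beyond the scatter in this assay. The expected change is a 1.4-fold lower number from compound 2 to compound 4 (0.15 log units; within the scatter) as an estimate, with only a weak lean toward a lower number. A limit reading for compound 4 also remains possible, given the limit of > 10000 nM in this assay, at which 1 of the 3 values shown sits, within this small set. For compound 4 the estimated value is 6000 nM within an expected range of 1500 nM to 20000 nM in this series.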

Compound 4, half-maximal inhibitory concentration: > 10000 nM
Compound 4: only a limit was reported (the forecaster's own chance of this, stated with the estimate: 30%); middle value at least 1.6-fold (0.22 log units) away from the limit.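

In this assay, within the data shown here, bromo in place of 2-methoxyphenyl gives an at least 1.1-fold higher number from compound 2 to compound 4 (0.07 log units; that floor lies within the scatter), the first step that changes one place only, and it has a floor rather than a size. Compound 4 reports a limit and not a number, so the result shows only that this single bromine, on an aromatic carbon next to the ring nitrogen, does not bring the reading below that limit. Readings of this kind now make up a large share of this small set, which restricts what further steps near the top of the range can show: the limit of > 10000 nM in this assay, at which 2 of the 4 values shown sit.

On these data alone, whether the loss of 2-methoxyphenyl costs anything at this position stays open, since the floor lies within the scatter and the true value of compound 4 is unknown. Nor do the compounds shown tell whether an amine or a carboxylic acid on this same carbon would give a reading below the limit, or whether any group here can move the number downward from that of compound 2.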